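The source may report more compounds than this note shows. Statements on the series, on what has been measured and on what is new or still open speak of the compounds shown alone.

Measured compounds:
- compound 1, `O=c1cc(-c2ccccc2)oc2cccc(OCCCN3CCC(O)CC3)c12`: 125 nM
- compound 2, `CN(C)CCCCOc1ccc2oc(-c3ccccc3)cc(=O)c2c1`: 720 nM
- compound 3, `CN(C)CCCCCCOc1ccc2oc(-c3ccccc3)cc(=O)c2c1`: 432 nM

In an assay on isolated protein (Cavia porcellus) with Sigma non-opioid intracellular receptor 1 (Homo sapiens) as the target, read by radioligand binding (on this read-out lower numbers stand for stronger inhibition and higher numbers for weaker inhibition), compound 3 stands second highest of the three numbers. Its nearest neighbour is compound 2, and the step of a 1.7-fold lower number from compound 2 to compound 3 (0.22 log units; within the scatter) lies within the scatter, so the two cannot be told apart. Compound 1 sits furthest away and gives 125 nM, a lower number than compound 3 by a margin beyond the scatter.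

Compound 4, `CN(C)CCCCCCCOc1ccc2oc(-c3ccccc3)cc(=O)c2c1`, is the next member of this chain series. The change from compound 3 is (dimethylamino)methyl in place of dimethylamino on a saturated chain carbon, six bonds along the chain from an oxygen on an aromatic ring. For the measured compounds named here, the only measured step that bears on it is the one from compound 2 to compound 3, the same kind of lengthening of the chain one position further in, and that step, a 1.7-fold lower number from compound 2 to compound 3 (0.22 log units; within the scatter), stayed within the scatter. On that basis no step beyond the scatter is expected in this assay for compound 4, with at most a slight drift towards a lower number, and the step from compound 3 to compound 4 is estimated as a 1.2-fold lower number from compound 3 to compound 4 (0.09 log units; within the scatter). Compound 4 is therefore expected to give about 350 nM, within a range from 150 nM to 800 nM.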

Compound 4, half-maximal inhibitory concentration: 165 nM
Compound 4: the middle estimate sits 2.1-fold (0.33 log units) above what was measured; the range from low to high includes it.
By their numbers in this assay, from the lowest: compounds 1 and 4 (each within the scatter of the next); then compounds 3 and 2 (each within the scatter of the next).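

In this assay, for the compounds shown here, the swap of dimethylamino for (dimethylamino)methyl at this place on the chain, six bonds along from the oxygen on the aromatic ring, is the first lengthening here to give a step that stands clear of the scatter: a 2.6-fold lower number from compound 3 to compound 4 (0.42 log units; beyond the scatter). The earlier lengthening, a 1.7-fold lower number from compound 2 to compound 3 (0.22 log units; within the scatter), could not separate its two compounds, so chain length at this end of the molecule had not yet been shown to matter in this assay. Taken across the series, the longest chain shown also stands clear of the shortest, with a 4.4-fold lower number from compound 2 to compound 4 (0.64 log units; beyond the scatter), so the chain does influence the number here, although no information is available on why this happens.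

The compounds shown leave open whether a longer chain than that of compound 4 would lower the number further, hold it level or raise it again. They also leave open whether a diethylamino group at the chain end, in place of dimethylamino, would respond to chain length in the same way.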